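This account rests on a few compounds, and the source may have more. Where it says the series, first, only, none or still open, it means among the compounds named here.

In a functional assay on T47D cells (Homo sapiens) for inhibition, read by CCK-8 assay, with a stated time of 72 h, tested at 1 uM (a lower number here means less inhibition of growth, a higher number more inhibition of growth at the concentration tested), compound 1 (`CN(C)C(=O)c1cc2cnc(Nc3ccc(NC(=O)C4(C(=O)Nc5cccc(F)c5)CC4)cc3)nc2n1C1CCCC1`) gives -3.2% while compound 2 (`CN(C)C(=O)c1cc2cnc(Nc3ccc(NC(=O)C4(C(=O)Nc5cccc(Cl)c5)CC4)cc3)nc2n1C1CCCC1`) gives 39.3% and compound 3 (`CN(C)C(=O)c1cc2cnc(Nc3ccc(NC(=O)C4(C(=O)Nc5ccc(Br)cc5)CC4)cc3)nc2n1C1CCCC1`) gives 21.1% and so stands second highest of the three. Compound 4 (`CN(C)C(=O)c1cc2cnc(Nc3ccc(NC(=O)C4(C(=O)Nc5ccc(C(F)(F)F)cc5)CC4)cc3)nc2n1C1CCCC1`) differs from compound 3 by one group, with trifluoromethyl in place of bromo on an aromatic carbon. Among the measured compounds shown here, no measured step makes this exact swap. The closest evidence is one large step (a number 42.5 percentage points higher from compound 1 to compound 2 (beyond the scatter)) and two modest ones (a number 24.3 percentage points higher from compound 1 to compound 3 (beyond the scatter)) and (a number 18.2 percentage points lower from compound 2 to compound 3 (beyond the scatter)). These show that swaps on this phenyl group can move the number well beyond the scatter, yet they point in no clear direction here, so the expectation stays close to compound 3 with a wide range. The expected step is (a number 2.1 percentage points lower from compound 3 to compound 4 (within the scatter)). Compound 4 is estimated at 19% (expected range -5% to 43%).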

Compound 4, percent growth inhibition at one concentration: 29.6%
Beside the measured number, compound 4's estimate is 10.6 percentage points below it, and the stated range covers the measured number.
By their numbers in this assay, from the lowest: compound 1; then compounds 3, 4 and 2 (each within the scatter of the next, the first and the last beyond it).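

Trifluoromethyl in place of bromo gives a number 8.5 percentage points higher from compound 3 to compound 4 (within the scatter), so in this assay these two groups cannot be told apart on this phenyl ring. Among the compounds shown here, the other comparisons give a number 9.7 percentage points lower from compound 2 to compound 4 (within the scatter) and a number 32.8 percentage points higher from compound 1 to compound 4 (beyond the scatter), so of the three earlier compounds only the one carrying 3-fluorophenyl stands clearly apart from the 4-(trifluoromethyl)phenyl compound. The data shown give no explanation for any of these differences. Still open, on these data alone, is how an amine or a carboxylic acid at this same place on the phenyl ring would read in this assay.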